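Trifluoromethyl for Chloro on the Benzylsulfanyl Arm

The compounds below may be only part of what the source reports. "The series", "measured", "known", "first", "only" and "open" are said of these compounds alone.

Compound 1 `Cc1cc(S(=O)(=O)/N=C(\N)n2nccc2-c2ccccc2)c(SCc2ccc(Cl)cc2)cc1Cl`: 12000 nM
Compound 2 `Cc1cc(S(=O)(=O)/N=C(\N)n2nccc2-c2ccccc2)c(SCc2ccccc2Cl)cc1Cl`: 20000 nM
Compound 3 `Cc1cc(-c2ccccc2)n(/C(N)=N/S(=O)(=O)c2cc(C)c(Cl)cc2SCc2ccc(C(F)(F)F)cc2)n1`: 18000 nM

In an ADME assay on HaCaT cells (Homo sapiens) for cytotoxicity, read by MTT assay, with a stated time of 72 h (on this read-out higher numbers stand for weaker inhibition and lower numbers for stronger inhibition), compound 1 gives the lowest of the three numbers, yet compound 3 and compound 2 both fall within the scatter of it, so no ranking among them can be drawn. Compound 4 `Cc1cc(S(=O)(=O)/N=C(\N)n2nccc2-c2ccccc2)c(SCc2ccc(C(F)(F)F)cc2)cc1Cl` differs from compound 1 in one place: trifluoromethyl in place of chloro on an aromatic carbon. Going by the values given here, the only measured step on this benzyl ring, a 1.7-fold higher number from compound 1 to compound 2 (0.22 log units; within the scatter), stays within the scatter. Compound 3 already carries the 4-(trifluoromethyl)benzyl group, though it differs from compound 4 elsewhere, and its value sits within the scatter of compound 1. Compound 4 is therefore expected to show no step beyond the scatter, a 1.3-fold higher number from compound 1 to compound 4 (0.10 log units; within the scatter). The estimate for compound 4 is 15000 nM, within 7000 nM to 32000 nM.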

Compound 4, half-maximal inhibitory concentration: 19000 nM
Compound 4: middle estimate off by 1.3-fold (0.10 log units), on the low side; low and high end bracket the measured number.
By their numbers in this assay, from the lowest: compounds 1, 3, 4 and 2 (each within the scatter of the next).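

In this assay, trifluoromethyl in place of chloro at this position gives a 1.6-fold higher number from compound 1 to compound 4 (0.20 log units; within the scatter), so this change on the benzylsulfanyl arm does not move the number beyond the scatter. The two other new comparisons agree: hydrogen in place of methyl on an aromatic carbon gives a 1.1-fold higher number from compound 3 to compound 4 (0.02 log units; within the scatter), and 4-(trifluoromethyl)phenyl in place of 2-chlorophenyl gives a 1.1-fold lower number from compound 2 to compound 4 (0.02 log units; within the scatter). No measurement bears on why these steps remain so small. On these data alone, whether an amine or a carboxylic acid at this position would step beyond the scatter remains open.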